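Cyclopropyl for cyclobutyl on the core: stability outlook

This account rests on a few compounds, and the source may have more. Where it says the series, first, only, none or still open, it means among the compounds named here.

Two compounds of the series have numbers in an ADME assay on microsomes from liver (Mus musculus) for metabolic stability, read by LC-MS, using NADPH, with a stated time of 10 min, tested at 10 uM; on this read-out lower numbers stand for a shorter-lived compound and higher numbers for a longer-lived compound. Compound 1 `Nc1ncnc2c1c(Oc1cc(C(F)(F)F)ccn1)nn2C1CCC1` gives 0.128 h in this assay and stands highest of the two, with compound 2 `Nc1ncnc2c1c(Oc1cc(Cl)ccn1)nn2C1CCC1` nearest at 0.0617 h. Among the compounds with values here, the only measured step in this assay, a 2.1-fold lower number from compound 1 to compound 2 (0.32 log units; beyond the scatter), concerns a change on the pyridine ring of the ether side.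

Compound 3 `Nc1ncnc2c1c(Oc1cc(C(F)(F)F)ccn1)nn2C1CC1` is not yet measured. It differs from compound 1 by cyclopropyl in place of cyclobutyl on an aromatic nitrogen. Within the data shown here, the measured step from compound 1 to compound 2 changes a different place on the shared core and so does not bear on this change; no measured pair alters the group on the aromatic nitrogen. With nothing in the numbers to point either way, the expectation for this assay is a step from compound 1 to compound 3 of no size beyond the scatter, a 1.0-fold higher number from compound 1 to compound 3 (0.01 log units; within the scatter), with the range widened to cover a modest move in either direction. Compound 3 is therefore estimated at 0.13 h, between 0.06 h and 0.28 h.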

Compound 3, half-life: > 2.41 h
Compound 3 gave a limit, no number (the forecaster's own chance of this, stated with the estimate: 5%); middle value at least 18-fold (1.26 log units) from the limit.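

In this assay, the group on the aromatic nitrogen proves to be a place of large effect: cyclopropyl in place of cyclobutyl comes with an at least 18-fold higher number from compound 1 to compound 3 (1.27 log units; beyond the scatter). Within the data shown here, the only earlier step, on the pyridine ring of the ether side, was modest at a 2.1-fold lower number from compound 1 to compound 2 (0.32 log units; beyond the scatter), so of the two places changed so far, the group on the aromatic nitrogen carries the larger step, and going from a four-membered to a three-membered carbon ring is enough to produce it. Compound 3 carries a limit of the assay and not a number: the limit of > 2.41 h in this assay, at which 1 of the 3 values shown sits.

The compounds shown do not tell whether the same ring change would give a step of similar size with chloro in place of trifluoromethyl, since the cyclopropyl group appears here only alongside trifluoromethyl. They also leave open whether the higher number is tied to the three-membered carbon ring itself, or would also appear with an open-chain group such as isopropyl, or with a ring holding oxygen such as oxetane, on the same aromatic nitrogen.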